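The source may hold more compounds than are shown below. What is called first, only, known or untested is meant among the compounds shown, and "the series" means these compounds.

Measured in a functional assay on SW-620 cells (Homo sapiens) for antiproliferative activity, read by MTT assay, with a stated time of 72 h; a lower number here means a stronger inhibitor, a higher number a weaker inhibitor:
Compound 1 `O=C1O/C(=C\Cn2cc(-c3cc(F)cc(F)c3)nn2)C(OCc2ccccc2)=C1OCc1ccccc1`: > 100000 nM (a limit)
Compound 2 `CCCCCc1ccc(-c2cn(C[C@H](O)[C@H]3OC(=O)C(OCc4ccccc4)=C3OCc3ccccc3)nn2)cc1`: 12200 nM

Among the compounds with values here, compound 2 gives the only actual number in this assay, 12200 nM. Compound 1 reads > 100000 nM, which is a limit of the assay and not a number.

Compound 3 `O=C1O[C@H]([C@@H](O)Cn2cc(C3CC3)nn2)C(OCc2ccccc2)=C1OCc1ccccc1` has not yet been measured. It carries cyclopropyl in place of 4-pentylphenyl on an aromatic carbon of a five-membered aromatic ring with 3 nitrogen (cyclopropyl in place of 4-pentylphenyl on an aromatic carbon). Within the data shown here, no measured step shows this change directly, so the expectation rests on thin evidence. Compound 1 also lacks 4-pentylphenyl and stands at > 100000 nM, a limit. A weakening beyond the scatter is therefore expected in this assay, and the estimated change is a 4.9-fold higher number from compound 2 to compound 3 (0.69 log units; beyond the scatter). For compound 3 the estimated value is 60000 nM, with an expected range from 22000 nM to 100000 nM.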

Compound 3, half-maximal inhibitory concentration: 54200 nM
For compound 3 the middle estimate is 1.1-fold (0.04 log units) above the measured one, and the stated range covers the measured number.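

In this assay, within the data shown here, the first direct reading at this position is a 4.4-fold higher number from compound 2 to compound 3 (0.65 log units; beyond the scatter). Exchanging 4-pentylphenyl for cyclopropyl on an aromatic carbon of the five-membered aromatic ring therefore weakens the compound, yet activity is not lost altogether, since compound 3 still gives a number. Compound 1 alone gives a limit and not a number: the limit of > 100000 nM in this assay, at which 1 of the 3 values shown sits.

Going by these compounds, only these two groups can be compared at this position, so it remains open whether the loss follows the six-membered aromatic ring, the pentyl chain or the overall size of the group. Plain phenyl, 4-methylphenyl or an aminomethyl group on the same carbon would help to separate these possibilities.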